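Adding Chlorine to a Compound That Shows No Activity

The source may hold more compounds than are shown below. What is called first, only, known or untested is meant among the compounds shown, and "the series" means these compounds.

Compound 1 `CCn1cc(-c2nc3ccccc3[nH]2)c(=O)c2cc(F)c(N3CCNCC3)cc21` was tested in a functional assay on HT-29 cells (Homo sapiens) for cytotoxicity, read by sulforhodamine B assay, with a stated time of 48 h; a lower number here means a stronger inhibitor, a higher number a weaker inhibitor. In this assay compound 1 gives > 10000 nM, which is a limit of the measurement rather than a number. Compound 2 `CCn1cc(-c2nc3ccccc3[nH]2)c(=O)c2cc(F)c(N3CCNCC3)nc21` was examined as well. In this assay compound 2 gives > 10000 nM, again only a limit. Going by the values given here, both values so far sit at the same limit, as the limit of > 10000 nM in this assay, at which 2 of the 2 values shown sit, records, and no step between measured compounds is available for comparison.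

Compound 3 `CCn1cc(-c2nc3ccc(Cl)cc3[nH]2)c(=O)c2cc(F)c(N3CCNCC3)cc21` has not yet been measured. It differs from compound 1 by a single change: chloro in place of hydrogen on an aromatic carbon. One chlorine atom takes the place of a hydrogen atom on an aromatic carbon of the fused two-ring system, turning 1H-benzimidazol-2-yl into 6-chloro-1H-benzimidazol-2-yl.

Among the compounds with values here, compound 1 sits at the limit in this assay, and no measured step points in either direction. The expected step that the limit leaves unreadable from compound 1 to compound 3 is none beyond the scatter. Compound 3 is therefore estimated at 15000 nM in this assay, within a range from 5000 nM to 50000 nM, and most likely reported again only as a limit.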

Compound 3, half-maximal inhibitory concentration: 4700 nM
The estimate for compound 3 lay 3.2-fold (0.50 log units) above the measured number; measured number outside the range, below it.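

In this assay, going by these compounds alone, compound 3 gives the only value shown that is a true reading rather than a limit, and the change from hydrogen to chloro comes with an at least 2.1-fold lower number from compound 1 to compound 3 (0.32 log units; beyond the scatter). This shows that a single atom placed on the six-membered aromatic ring of carbon only can move the result at this position, something that compounds sitting at one shared limit could not reveal. On these data alone, the real size of the step remains unknown and could be larger than the printed figure, because its starting point is a limit and not a number: the limit of > 10000 nM in this assay, at which 2 of the 3 values shown sit.

As far as these compounds go, it remains open whether this shift belongs to chlorine in particular or would also appear with another group at the same place, such as a methoxy group, an amine or a carboxylic acid. From the compounds shown here alone, it is also open whether chloro in the same place would have a similar effect on compound 2, which shares the 1H-benzimidazol-2-yl group of compound 1 and also gives only a limit.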